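This account rests on a few compounds, and the source may have more. Where it says the series, first, only, none or still open, it means among the compounds named here.

In an ADME assay on microsomes from liver (Rattus norvegicus) for metabolic stability (on this read-out higher numbers stand for a longer-lived compound and lower numbers for a shorter-lived compound), compound 1 (`Nc1nc(NCCNc2ncc(-c3ncc[nH]3)c(-c3ccccc3Br)n2)ccc1[N+](=O)[O-]`) gives > 0.5 h, which is a limit and not a number. Compound 2 (`Nc1nc(NCCNc2ncc(-c3ncc[nH]3)c(-c3ccc(Br)cc3F)n2)ccc1[N+](=O)[O-]`) gives > 0.5 h, also only a limit. Compound 3 (`Nc1nc(NCCNc2ncc(-c3ncc[nH]3)c(-c3cc(F)c(Cl)cc3Cl)n2)ccc1[N+](=O)[O-]`) replaces the 4-bromo-2-fluorophenyl of compound 2 with 2,4-dichloro-5-fluorophenyl: 2,4-dichloro-5-fluorophenyl in place of 4-bromo-2-fluorophenyl on an aromatic carbon. For the measured compounds named here, the only measured step that bears on this change is a step that the two limits leave unreadable from compound 1 to compound 2, so it offers no size to carry over, and no shift beyond the scatter is expected in this assay. The expected step is a step that the limit leaves unreadable from compound 2 to compound 3. For compound 3, the estimated half-life is 0.7 h, with an expected range of 0.4 h to 1.4 h.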

Compound 3, half-life: > 0.5 h
Compound 3 ended at the assay's limit (the forecaster's own chance of this, stated with the estimate: 75%); the middle value does not contradict the limit.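

For the compounds shown here, no step between compound 1, compound 2 and compound 3 can be read in this assay, because all three stop at one limit: the limit of > 0.5 h in this assay, at which 3 of the 3 values shown sit. From the compounds shown here alone, how long each half-life actually runs, and whether the phenyl changes alter it, stays open.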